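The compounds below may be only part of what the source reports. "The series", "measured", "known", "first", "only" and "open" are said of these compounds alone.

Measured so far:
- compound 1, `CN(C(=O)NC(=O)c1ccc(F)c(F)c1)c1nc(C(F)(F)F)c(C(=O)N/N=C/c2ccc(C(F)(F)F)cc2)s1` — 6.07 ug/mL in a functional assay on A549 cells (Homo sapiens) for inhibition, read by MTT assay, with a stated time of 72 h; on this read-out higher numbers stand for weaker inhibition and lower numbers for stronger inhibition
- compound 2, `CN(C(=O)NC(=O)c1ccc(Cl)cc1Cl)c1nc(C(F)(F)F)c(C(=O)N/N=C/c2ccc(C(F)(F)F)cc2)s1` — 9.4 ug/mL
- compound 3, `CN(C(=O)NC(=O)c1ccc(F)c(F)c1)c1nc(C(F)(F)F)c(C(=O)N/N=C/c2cc(C(F)(F)F)cc(C(F)(F)F)c2)s1` — 5.47 ug/mL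

Compound 2 is compound 1 with one change, (2,4-dichlorophenyl in place of 3,4-difluorophenyl on a carbonyl carbon), and that change gave a 1.5-fold higher number from compound 1 to compound 2 (0.19 log units; within the scatter). Compound 3 shares the same framework, but how its core differs from the core of compound 1 is not broken down here; the values of compound 1 and compound 3 lie within the usual scatter of each other, so no order between them can be read. Compound 4, `CN(C(=O)NC(=O)c1ccc(Cl)cc1Cl)c1nc(C(F)(F)F)c(C(=O)N/N=C/c2cc(C(F)(F)F)cc(C(F)(F)F)c2)s1`, is compound 3 with the same change applied: 2,4-dichlorophenyl in place of 3,4-difluorophenyl on a carbonyl carbon. Because the earlier step was a 1.5-fold higher number from compound 1 to compound 2 (0.19 log units; within the scatter), the same change on compound 3 is expected to give a step of about a 1.5-fold higher number from compound 3 to compound 4 (0.18 log units; within the scatter) in this assay. Compound 4 is therefore estimated at 8.2 ug/mL, most likely between 4 ug/mL and 17 ug/mL.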

Compound 4, half-maximal inhibitory concentration: > 100 ug/mL
Compound 4 ended at the assay's limit; the forecaster's own chance of this, stated with the estimate: 5%; middle value at least 12-fold (1.08 log units) from the limit.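

In this assay, putting 2,4-dichlorophenyl in place of 3,4-difluorophenyl on a carbonyl carbon gave an at least 18-fold higher number from compound 3 to compound 4 (1.26 log units; beyond the scatter). The value of compound 4, > 100 ug/mL, is a limit of the assay and not a number. The change therefore did not carry over from one core to the other at the same size, although two pairs cannot show why, or how it would behave on any further core: the same change on two cores in this assay, a 1.5-fold higher number (0.19 log units; within the scatter) from compound 1 to compound 2 and an at least 18-fold higher number (1.26 log units; beyond the scatter) from compound 3 to compound 4, at least 11-fold (1.07 log units) apart, beyond the scatter of two such steps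

The compounds shown leave open whether a plain phenyl or a 4-methoxyphenyl group on that carbonyl carbon would give a similarly large step on the core of compound 3. They also leave open whether a single chlorine on the phenyl ring would do so.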